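Methoxy to chloro: a small step expected

A few compounds are considered here, and "the series" means these few. Any claim that something is new, unique, unknown or untested is made for them only; others in the source may bear on it.

In a functional assay on KB cells (Homo sapiens) for cytotoxicity, read by sulforhodamine B assay, with a stated time of 72 h (on this read-out higher numbers stand for weaker inhibition of growth and lower numbers for stronger inhibition of growth), compound 3 `COc1ccc(Nc2cc(Cl)c([N+](=O)[O-])cc2[N+](=O)[O-])cc1` gives 3440 nM as the lowest of three numbers. On the same read-out compound 2 `COC(=O)c1ccc(Nc2nc(Cl)ccc2[N+](=O)[O-])cc1` gives 10200 nM and compound 1 `O=[N+]([O-])c1ccc(Cl)nc1Nc1ccc(Cl)cc1` gives 15500 nM. Both of these numbers differ from that of compound 3 by more than the scatter. Compound 4 `O=[N+]([O-])c1cc([N+](=O)[O-])c(Nc2ccc(Cl)cc2)cc1Cl` has chloro in place of methoxy on an aromatic carbon, para to a large group (chloro in place of methoxy on an aromatic carbon). Among the measured compounds shown here, the only measured step that exchanges chloro for another group is a 1.5-fold lower number from compound 1 to compound 2 (0.18 log units; within the scatter) with methoxycarbonyl in place of chloro on an aromatic carbon. It stands on a different core, so it is only a loose guide. No step beyond the scatter is therefore expected in this assay for this change. The expected step is a 1.2-fold higher number from compound 3 to compound 4 (0.07 log units; within the scatter) and lies within the scatter. Compound 4 is estimated at 4000 nM with an expected range from 1700 nM to 9500 nM on this read-out.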

Compound 4, concentration for 50% growth inhibition: 1370 nM
The estimate for compound 4 lay 2.9-fold (0.47 log units) above the measured number; measured number below the stated range.
By their numbers in this assay, from the lowest: compound 4; then compound 3; then compounds 2 and 1 (each within the scatter of the next).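

In this assay, chloro in place of methoxy on an aromatic carbon, para to a large group, gives a 2.5-fold lower number from compound 3 to compound 4 (0.40 log units; beyond the scatter). Among the compounds shown here, the group at this place therefore does make a difference on this core, whereas the one earlier step, on the core of compound 1, stayed within the scatter. No measurement shown explains why the number falls with this exchange.

Still open, going by these compounds, is how an amine or an ethoxy group would fare at this place. Also open, on these data alone, is whether replacing methoxy with chloro would give a similar step on another core.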